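Replacing 1H-benzimidazol-2-yl with benzyl on the sulfur chain

This account rests on a few compounds, and the source may have more. Where it says the series, first, only, none or still open, it means among the compounds named here.

In a functional assay on HGC-27 cells (Homo sapiens) for inhibition, read by MTT assay, with a stated time of 72 h (on this read-out lower numbers stand for stronger inhibition and higher numbers for weaker inhibition), compound 1 `Cc1cc(N2CC[C@@H](C)[C@@H](N(C)c3ncnc4[nH]ccc34)C2)n2nc(SCC3CC3)nc2n1` gives 21400 nM. Compound 2 `Cc1cc(N2CC[C@@H](C)[C@@H](N(C)c3ncnc4[nH]ccc34)C2)n2nc(SCc3nc4ccccc4[nH]3)nc2n1` gives > 100000 nM, which is a limit of the assay and not a number. Compound 3 `C[C@@H]1CCN(c2cc(-c3ccccc3)nc3ncnn23)C[C@@H]1N(C)c1ncnc2[nH]ccc12` gives > 100000 nM, which is also a limit. As far as these compounds go, compound 2 therefore stands at the limit of > 100000 nM in this assay, at which 2 of the 3 values shown sit, so how weak it truly is remains unknown.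

Compound 4 `Cc1cc(N2CC[C@@H](C)[C@@H](N(C)c3ncnc4[nH]ccc34)C2)n2nc(SCCc3ccccc3)nc2n1` is still to be measured in this assay. Its change from compound 2 is benzyl in place of 1H-benzimidazol-2-yl on a saturated chain carbon bound to a sulfur. Among the compounds with values here, the one measured step that bears on this is an at least 4.6-fold higher number from compound 1 to compound 2 (0.66 log units; beyond the scatter), which came with 1H-benzimidazol-2-yl replacing cyclopropyl at that same place. Within the data shown here, compound 4 loses that group again, so part of that loss may be expected to return, though benzyl is not cyclopropyl and no measured compound carries it. A lower number than for compound 2 is therefore expected, with a real chance that compound 4 also ends at the limit. The expected size of the change is an at least 2.5-fold lower number from compound 2 to compound 4 (0.39 log units; beyond the scatter). The estimate for compound 4 is 40000 nM, with an expected range of 12000 nM to 100000 nM.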

Compound 4, half-maximal inhibitory concentration: 11800 nM
The estimate for compound 4 lay 3.4-fold (0.53 log units) above the measured number; the whole stated range lies above it.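

In this assay, exchanging 1H-benzimidazol-2-yl for benzyl on the saturated chain carbon bound to a sulfur gives an at least 8.4-fold lower number from compound 2 to compound 4 (0.92 log units; beyond the scatter), so an aromatic ring on this chain does not by itself bring the loss seen with compound 2. Exchanging cyclopropyl for benzyl at the same place gives a 1.8-fold lower number from compound 1 to compound 4 (0.26 log units; within the scatter), so compound 1 and compound 4 cannot be told apart here, and this position accepts both of these quite different groups with no measurable change. Among the three groups compared at this place, only 1H-benzimidazol-2-yl goes with a large loss, but the full size of that loss stays unknown, as compound 2 has a limit of the assay and not a number: the limit of > 100000 nM in this assay, at which 2 of the 4 values shown sit.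

Benzyl differs from 1H-benzimidazol-2-yl in its ring count, its nitrogen atoms and its hydrogen-bond donor, and the compounds shown do not separate these differences. A 1H-imidazol-2-yl group or a pyridin-2-yl group at this place could show which of them matters, and a carboxylic acid or a longer chain could show how far the position's tolerance extends.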